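Swapping a ring for a fluorinated chain on the core

The source may hold more compounds than are shown below. What is called first, only, known or untested is meant among the compounds shown, and "the series" means these compounds.

In an ADME assay on the whole organism (plasma) for pharmacokinetics, with Rattus norvegicus as the target, with a stated time of 24 h, at a dose of 10 mg/kg by the oral route (a higher number here means more compound in the circulation at the dose given, a lower number less compound in the circulation), two compounds have been measured:
- Compound 1 `CCc1ccc2c(c1)c(-c1ccc[nH]c1=O)c(C(=O)NS(=O)(=O)C1CC1)n2Cc1cc(F)ccc1F` gives 6140 ng.h/mL
- Compound 2 `CC1(c2ccc3c(c2)c(-c2ccc[nH]c2=O)c(C(=O)NS(=O)(=O)C2CC2)n3Cc2cc(F)ccc2F)CC1` gives 5910 ng.h/mL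

These two numbers lie within the usual scatter of each other, so compound 2 stands level with compound 1. The next structure is compound 3 `O=C(NS(=O)(=O)C1CC1)c1c(-c2ccc[nH]c2=O)c2cc(CC(F)(F)F)ccc2n1Cc1cc(F)ccc1F`, which has 2,2,2-trifluoroethyl in place of 1-methylcyclopropyl on an aromatic carbon. Among the compounds with values here, only one measured step bears on this change: a 1.0-fold lower number from compound 1 to compound 2 (0.02 log units; within the scatter), with 1-methylcyclopropyl in place of ethyl. That single step is small, but it says nothing directly about a fluorinated chain, so the expectation is uncertain. No step beyond the scatter is expected in this assay, in either direction. The expected step is a 1.2-fold lower number from compound 2 to compound 3 (0.07 log units; within the scatter). For compound 3 the estimate is 5000 ng.h/mL, with an expected range from 2200 ng.h/mL to 11000 ng.h/mL.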

Compound 3, area under the concentration-time curve: 379 ng.h/mL
Compound 3: middle estimate off by 13-fold (1.12 log units), on the high side, outside the stated range (below it).
By their numbers in this assay, from the lowest: compound 3; then compounds 2 and 1 (each within the scatter of the next).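

In this assay, this position on the shared core is far from indifferent: 1-methylcyclopropyl and ethyl stand level, yet 2,2,2-trifluoroethyl in place of 1-methylcyclopropyl gives a 16-fold lower number from compound 2 to compound 3 (1.19 log units; beyond the scatter). The closest comparison is with the ethyl group, where trifluoromethyl in place of methyl on the chain gives a 16-fold lower number from compound 1 to compound 3 (1.21 log units; beyond the scatter), so changing only the end of that chain is enough to bring a large drop. Nothing available here explains why the number falls.

As far as these compounds go, it remains open whether the drop needs full fluorination of the chain end, or whether a 2-fluoroethyl or 2,2-difluoroethyl group would stay level with ethyl. From the compounds shown here alone, it is also open how a methoxy group or a longer fluorinated chain, such as 3,3,3-trifluoropropyl, would behave at this position.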